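Adding a Methoxy to Compound 3

The compounds below may be only part of what the source reports. "The series", "measured", "known", "first", "only" and "open" are said of these compounds alone.

In a functional assay on A549 cells (Homo sapiens) for cytotoxicity, read by MTT assay, with a stated time of 6 days (a lower number here means that less compound is needed, a higher number that more compound is needed for the effect), compound 3 `COC(=O)c1c(-c2ccc([N+](=O)[O-])cc2)oc2ccccc2c1=O` gives > 25 ug/mL, which is a limit and not a number. Compound 1 `COC(=O)c1c(-c2ccc(OC)cc2)oc2ccccc2c1=O` gives > 25 ug/mL, also a limit. Compound 2 `COC(=O)c1c(-c2ccc(Br)cc2)oc2ccccc2c1=O` gives > 25 ug/mL, again a limit. Compound 4 `COC(=O)c1c(-c2ccc([N+](=O)[O-])cc2)oc2cc(OC)ccc2c1=O` differs from compound 3 by methoxy in place of hydrogen on an aromatic carbon, with methoxy in place of hydrogen on an aromatic carbon. Going by the values given here, three measured steps bear on this only indirectly: a step that the two limits leave unreadable from compound 1 to compound 2, a step that the two limits leave unreadable from compound 1 to compound 3 and a step that the two limits leave unreadable from compound 2 to compound 3. None has a readable size, and none changes this carbon. Compound 4 is therefore expected to stay near compound 3, with no step beyond the scatter, because of the limit of > 25 ug/mL in this assay, at which 3 of the 3 values shown sit. The expected size is a step that the limit leaves unreadable from compound 3 to compound 4. Compound 4 is estimated at 30 ug/mL, within an expected range of 12 ug/mL to 60 ug/mL.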

Compound 4, concentration for half-maximal effect: > 25 ug/mL
Compound 4 gave a limit, no number (the forecaster's own chance of this, stated with the estimate: 75%); the middle value lies beyond the limit too.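

Compound 3 and compound 4 both give a limit and not a number, so no step between them can be read: the limit of > 25 ug/mL in this assay, at which 4 of the 4 values shown sit.

The compounds shown leave open whether adding methoxy, or any other change among them, alters the concentration needed in this assay.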